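This account rests on a few compounds, and the source may have more. Where it says the series, first, only, none or still open, it means among the compounds named here.

Measured so far in a functional assay on MIA PaCa-2 cells (Homo sapiens) for antiproliferative activity, read by sulforhodamine B assay, with a stated time of 48 h (on this read-out lower numbers stand for stronger inhibition and higher numbers for weaker inhibition), for two compounds:
Compound 1 `COc1cc(C(=O)/C=C\Nc2ccc(-c3nc4cc(OC)c(OC)c(OC)c4s3)cc2C)cc([N+](=O)[O-])c1OC` gives 22000 nM
Compound 2 `COc1cc(C(=O)/C=C\Nc2ccc(-c3nc4cc(OC)c(OC)c(OC)c4s3)cc2)cc([N+](=O)[O-])c1OC` gives 15800 nM

Among the compounds with values here, compound 1 stands level with compound 2, the only other measured compound. Compound 3 `COc1cc(C(=O)/C=C\Nc2ccc(-c3nc4cc(OC)c(OC)c(OC)c4s3)cc2C)cc(OC)c1OC` carries methoxy in place of nitro on an aromatic carbon and is otherwise the same as compound 1. Within the data shown here, the one measured step, a 1.4-fold lower number from compound 1 to compound 2 (0.14 log units; within the scatter) for hydrogen in place of methyl, does not exchange nitro, so nothing measured tests this change. No step beyond the scatter is therefore expected in this assay with any confidence, and the range stays wide. The expected change is an estimated 1.8-fold lower number from compound 1 to compound 3 (0.26 log units; within the scatter). Compound 3 is estimated at 12000 nM (expected range 2500 nM to 35000 nM).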

Compound 3, half-maximal inhibitory concentration: 22800 nM
The estimate for compound 3 lay 1.9-fold (0.28 log units) below the measured number, within the range that was stated.
By their numbers in this assay, from the lowest: compounds 2, 1 and 3 (each within the scatter of the next).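

Methoxy in place of nitro on this aromatic carbon gives a 1.0-fold higher number from compound 1 to compound 3 (0.02 log units; within the scatter) in this assay and so, for the first time, tests this position. With compound 1 as the reference, exchanging nitro for methoxy here leaves the number within the scatter, so nitro is not required at this position for the level seen with compound 1. No evidence given here bears on this result.

The compounds shown leave open whether an amine or a carboxylic acid on this carbon would move the number beyond the scatter. They also do not show whether any change to the shared core would do so.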